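From a Hydroxyalkylamino Chain to a Piperidine Ring

A few compounds are considered here, and "the series" means these few. Any claim that something is new, unique, unknown or untested is made for them only; others in the source may bear on it.

In a functional assay on MCF7 cells (Homo sapiens) for cytotoxicity, read by fluorescence, with a stated time of 72 h (on this read-out lower numbers stand for stronger inhibition and higher numbers for weaker inhibition), compound 1 `CC(C)c1n[nH]c2c(NCc3ccc(-c4ccccn4)cc3)nc(S(C)(=O)=O)nc12`, which carries methylsulfonyl on the shared core, gives 460 nM. Compound 2 `CC(C)c1n[nH]c2c(NCc3ccc(-c4ccccn4)cc3)nc(NCCO)nc12`, with (2-hydroxyethyl)amino at that place, gives 51 nM. Compound 3 `CC(C)c1n[nH]c2c(NCc3ccc(-c4ccccn4)cc3)nc(NCC(C)(C)O)nc12`, with (2-hydroxy-2-methylpropyl)amino, gives 24 nM, the lowest of these three numbers.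

Compound 4 `CC(C)c1n[nH]c2c(NCc3ccc(-c4ccccn4)cc3)nc(N3CCCCC3CCO)nc12` changes the same aromatic carbon, between two ring nitrogen atoms: 2-(2-hydroxyethyl)piperidin-1-yl replaces (2-hydroxy-2-methylpropyl)amino, as counted here: 2-(2-hydroxyethyl)piperidin-1-yl in place of (2-hydroxy-2-methylpropyl)amino on an aromatic carbon. Among the compounds with values here, three measured steps bear on this. Replacing methylsulfonyl gave a 9.0-fold lower number from compound 1 to compound 2 (0.96 log units; beyond the scatter) and a 19-fold lower number from compound 1 to compound 3 (1.28 log units; beyond the scatter), so both hydroxyl-bearing amino groups gave clear gains over compound 1. Changing the chain itself gave a much smaller step, a 2.1-fold lower number from compound 2 to compound 3 (0.33 log units; beyond the scatter). The new group also keeps a hydroxyl-bearing chain, which suggests that compound 4 should stay close to compound 3 and far from compound 1. Within the data shown here, still, no measured compound has a ring at this place, so the data leave that part of the change untested. In this assay, the expected step is small, with no clear move beyond the scatter: a 1.3-fold higher number from compound 3 to compound 4 (0.10 log units; within the scatter). For compound 4 the estimated value is 30 nM, with an expected range from 8 nM to 110 nM.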

Compound 4, half-maximal inhibitory concentration: 133 nM
Compound 4: the middle estimate sits 4.4-fold (0.65 log units) below what was measured; measured number above the stated range.
By their numbers in this assay, from the lowest: compound 3; then compound 2; then compound 4; then compound 1.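

In this assay a hydroxyl-bearing chain alone does not carry the gain seen with the open groups: the ring-containing group gives a 5.5-fold higher number from compound 3 to compound 4 (0.74 log units; beyond the scatter) and also a 2.6-fold higher number from compound 2 to compound 4 (0.42 log units; beyond the scatter) at this same aromatic carbon. The replacement of methylsulfonyl still pays, with a 3.5-fold lower number from compound 1 to compound 4 (0.54 log units; beyond the scatter) as the step, but this is a smaller gain than either open hydroxyl-bearing amino group gave, so what is attached through the nitrogen at this carbon matters and not only the presence of a hydroxyl. Several things differ at once, since 2-(2-hydroxyethyl)piperidin-1-yl has a six-membered non-aromatic ring and 1 hydrogen-bond donor where (2-hydroxy-2-methylpropyl)amino has no ring and 2, and no measurement shown here explains why the number rises.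

The compounds shown leave open whether the ring itself or the loss of the amino hydrogen accounts for the step. An open N-methyl-(2-hydroxyethyl)amino group would separate those two, while plain piperidin-1-yl and 4-hydroxypiperidin-1-yl would show what the hydroxyl and its placement on the ring contribute.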